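Chloro in place of trifluoromethyl on a diaryl urea

A few compounds are considered here, and "the series" means these few. Any claim that something is new, unique, unknown or untested is made for them only; others in the source may bear on it.

Compound 1 `COc1cc2cc(Oc3ccc(NC(=O)Nc4cccc(C(F)(F)F)c4)cc3)c(C)nc2cc1OC` gives > 50000 nM in a functional assay on SNB-19 cells (Homo sapiens) for inhibition, read by sulforhodamine B assay, with a stated time of 48 h (on this read-out higher numbers stand for lower toxicity in this test and lower numbers for higher toxicity in this test), a limit of the assay.
Compound 2 `COc1cc2cc(Oc3ccc(NC(=O)Nc4ccc(Cl)c(C(F)(F)F)c4)cc3)c(C)nc2cc1OC` gives 15000 nM in this assay.

Compound 2 thus holds the only true number shown, while compound 1 stops at a limit. The step of an at least 3.3-fold lower number from compound 1 to compound 2 (0.52 log units; beyond the scatter) came from adding a chloro to an aromatic carbon. Compound 3 `COc1cc2cc(Oc3ccc(NC(=O)Nc4ccc(Cl)c(Cl)c4)cc3)c(C)nc2cc1OC` differs from compound 2 by chloro in place of trifluoromethyl on an aromatic carbon. Within the data shown here, no measured step touches this trifluoromethyl group, and the one known step alters a different spot, so the step of no change at the digits printed from compound 2 to compound 3 (within the scatter) is expected to stay within the scatter. Compound 3 is therefore estimated at 15000 nM, between 5000 nM and 50000 nM.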

Compound 3, concentration lethal to 50% of the cells: > 100000 nM
Compound 3: only a limit was reported (the forecaster's own chance of this, stated with the estimate: 25%); middle value at least 6.6-fold (0.82 log units) away from the limit.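

Replacing trifluoromethyl with chloro on this ring is not a neutral swap in this assay: the change gives an at least 6.6-fold higher number from compound 2 to compound 3 (0.82 log units; beyond the scatter). With the 4-chloro group held constant, the trifluoromethyl group therefore counts toward the lower number of compound 2, something the earlier step, made at a different spot, could not show. The value of compound 3 is a limit of the assay, not a number: the limit of > 100000 nM in this assay, at which 1 of the 3 values shown sits.

Compound 1 and compound 3 both stop at limits, so the step between them cannot be read. As far as these compounds go, how a nitrile or an amine would fare at this spot remains open.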